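Notes on a substituent swap in a deubiquitinase series

The source may report more compounds than this note shows. Statements on the series, on what has been measured and on what is new or still open speak of the compounds shown alone.

Measured compounds:
compound 1 `O=c1c2cnn(-c3ccc(F)cc3)c2ncn1CC1(O)CCN(Cc2ccncc2)CC1`: "not determined" (no result reported) in an assay on Sf21 cells for inhibition of ubiquitin carboxyl-terminal hydrolase 7 (Homo sapiens), read by spectrophotometry, with stated times of 30 min and 2 h; a lower number here means a stronger inhibitor, a higher number a weaker inhibitor
compound 2 `O=c1c2cnn(-c3ccc(F)cc3)c2ncn1CC1(O)CCN(Cc2ccccc2Cl)CC1`: 3400 nM

Among the compounds with values here, compound 1 cannot be placed on the numbers, since no value was reported for it, and no step between measured compounds exists to set a scale. Compound 3 `COC(=O)c1ccc(CN2CCC(O)(Cn3cnc4c(cnn4-c4ccc(F)cc4)c3=O)CC2)c(F)c1` carries the change (2-fluoro-4-(methoxycarbonyl)phenyl in place of pyridin-4-yl on a saturated chain carbon bound to an amine nitrogen in a ring). The step from compound 1 to compound 3 in this assay is expected to be small, no clear direction beyond the scatter, with compound 2 as the only measured anchor for what this series gives. Compound 3 is estimated at 2500 nM, with an expected range of 600 nM to 10000 nM.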

Compound 3, half-maximal inhibitory concentration: 800 nM
Estimate against measurement, compound 3: 3.1-fold (0.49 log units) above, and the stated range covers the measured number.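

In this assay, this position on a saturated chain carbon bound to an amine nitrogen in a ring now shows a readable response to the aryl group: 2-fluoro-4-(methoxycarbonyl)phenyl in place of 2-chlorophenyl gives a 4.3-fold lower number from compound 2 to compound 3 (0.63 log units; beyond the scatter). The change from pyridin-4-yl cannot be read, as compound 1 has no value. Nothing available accounts for the step. The swap changes the halogen and adds the methyl ester together, so their separate contributions remain unresolved. Also open, going by these compounds, is whether a carboxylic acid or a primary amide in place of the methyl ester would keep the number.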